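This account rests on a few compounds, and the source may have more. Where it says the series, first, only, none or still open, it means among the compounds named here.

Of the compounds shown here, three have been read in an ADME assay on HEK-293T cells (Homo sapiens) for cytotoxicity, read by CCK-8 assay, with a stated time of 48 h; a higher number here means a weaker inhibitor, a lower number a stronger inhibitor. Compound 1 `O=C(NCCNS(=O)(=O)c1ccc(-c2ccccc2O[C@H]2CC[C@H](O)CC2)s1)Nc1ccc([N+](=O)[O-])cc1` gives 9000 nM and compound 3 `COc1ccc(Oc2ccccc2-c2ccsc2S(=O)(=O)NCCNC(=S)Nc2cc(C(F)(F)F)cc(C(F)(F)F)c2)cc1OC` gives 6800 nM, two values within the usual scatter of each other.

Compound 2 `COc1cccc(NC(=O)NCCNS(=O)(=O)c2ccc(-c3ccccc3OCc3ccccc3)s2)c1` gives > 20000 nM, which is a limit of the assay and not a number. Compound 2 therefore has no exact position among the numbers, and it stands at the limit of > 20000 nM in this assay, at which 1 of the 3 values shown sits.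

Compound 4 `O=S(=O)(NCCNC(=S)Nc1ccc(Cl)cc1)c1ccc(-c2ccccc2OCc2ccccc2)s1` keeps the core of compound 2 and changes one group: a group of 10 heavy atoms (7 carbon, 1 nitrogen, 1 sulfur, 1 chlorine; one six-membered aromatic ring of carbon only) in place of a group of 11 heavy atoms (8 carbon, 1 nitrogen, 2 oxygen; one six-membered aromatic ring of carbon only), on an amine nitrogen. The (3-methoxyphenyl)carbamoyl group leaves, and the group that enters brings sulfur and chlorine, on an amine nitrogen whose other neighbours are: saturated chain carbon.

For the measured compounds named here, no measured pair differs in one place only, so the size of this step has no direct precedent. Compound 3 also carries sulfur in its group on that amine nitrogen and gives 6800 nM, so a move toward a lower number is expected in this assay. A second limit reading remains possible. The expected change is an at least 2.0-fold lower number from compound 2 to compound 4 (0.30 log units; that floor lies within the scatter). For compound 4 the estimated value is 10000 nM, with an expected range of 4000 nM to 22000 nM.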

Compound 4, half-maximal inhibitory concentration: 12100 nM
Estimate against measurement, compound 4: 1.2-fold (0.08 log units) below, and the stated range covers the measured number.
By their numbers in this assay, from the lowest: compounds 3, 1 and 4 (each within the scatter of the next). At a limit, above all of these: compound 2.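

For the compounds shown here, this is the first one-place change, and it falls on the amine nitrogen whose other neighbour is a saturated chain carbon: in this assay, replacing the (3-methoxyphenyl)carbamoyl group on the core of compound 2 gives a measurable number, with compound 4 at 12100 nM. The reading for compound 2 is a limit of the assay and not a number, so the size of the change is known only as a floor, and that floor, an at least 1.6-fold lower number from compound 2 to compound 4 (0.21 log units; that floor lies within the scatter), is printed as within the scatter; the pair therefore shows that this position can carry a change that brings the reading off the limit, but it does not establish a shift beyond the usual scatter, and the limit itself stands as follows: the limit of > 20000 nM in this assay, at which 1 of the 4 values shown sits.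
The step also moves several atoms at once, with sulfur and chlorine entering as the oxygens leave, so it assigns the result to no single atom.

Still open, from the compounds shown here alone, is how the number moves on this core with sulfur alone or chlorine alone in the group on that nitrogen. Also open, going by these compounds, is how this assay reads when that nitrogen carries a group with no aromatic ring, such as a longer alkyl chain or a carboxylic acid.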